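The compounds below may be only part of what the source reports. "The series", "measured", "known", "first", "only" and "open" are said of these compounds alone.

Compound 1, whose structure is `Cc1cc(Cl)c(S(C)(=O)=O)cc1C(=O)N=C(N)N`, gives 25 nM in a functional assay for inhibition of sodium/hydrogen exchanger (Oryctolagus cuniculus); a higher number here means a weaker inhibitor, a lower number a stronger inhibitor. Compound 2, drawn as `CS(=O)(=O)c1cc(C(=O)N=C(N)N)c(Cl)cc1Cl`, gives 140 nM in this assay; it differs from compound 1 by a single change, (chloro in place of methyl on an aromatic carbon), and this shift produced a 5.6-fold higher number from compound 1 to compound 2 (0.75 log units; beyond the scatter). Compound 3, of structure `Cc1ccc(C(=O)N=C(N)N)cc1S(C)(=O)=O`, gives 210 nM in this assay; how its core differs from that of compound 1 is not broken down here, and against compound 2 its value lies within the scatter.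

Compound 4, drawn as `CS(=O)(=O)c1cc(C(=O)N=C(N)N)ccc1Cl`, has not yet been measured. It differs from compound 3 by chloro in place of methyl on an aromatic carbon. This is the same kind of change as that between compound 1 and compound 2, but not the same: there the place was ortho to a group of 6 heavy atoms, meta to a chloro group and para to a methylsulfonyl group, whereas here it is ortho to a methylsulfonyl group and para to a group of 6 heavy atoms.

Among the measured compounds shown here, the only measured example of this change is the modest weakening seen in a 5.6-fold higher number from compound 1 to compound 2 (0.75 log units; beyond the scatter). For compound 4 a smaller step in the same direction is expected, estimated as a 1.9-fold higher number from compound 3 to compound 4 (0.28 log units; within the scatter). The surroundings differ, so this expectation rests on a single precedent and carries a wide range. In this assay compound 4 is therefore estimated at 400 nM, most likely between 150 nM and 1200 nM.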

Compound 4, half-maximal inhibitory concentration: 380 nM
Beside the measured number, compound 4's estimate is 1.1-fold (0.02 log units) above it; low and high end bracket the measured number.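

In this assay, chloro in place of methyl does not have one size across the two cores: the same change on two cores in this assay, a 5.6-fold higher number (0.75 log units; beyond the scatter) from compound 1 to compound 2 and a 1.8-fold higher number (0.26 log units; within the scatter) from compound 3 to compound 4, 3.1-fold (0.49 log units) apart, beyond the scatter of two such steps
On the core of compound 3 the change gives a 1.8-fold higher number from compound 3 to compound 4 (0.26 log units; within the scatter), so compound 3 and compound 4 cannot be told apart, and the clear step on the core of compound 1 cannot be carried over at full size, although the changes elsewhere on the ring do register, with hydrogen in place of chloro giving a 2.7-fold higher number from compound 2 to compound 4 (0.43 log units; beyond the scatter) and hydrogen in place of methyl giving a 15-fold higher number from compound 1 to compound 4 (1.18 log units; beyond the scatter). This shows that the effect of the change depends on the core in this series, but two pairs give no reason for the gap and cannot show how the change would behave on a third core.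

The compounds shown leave open whether a third core would resemble that of compound 1 or that of compound 3, and whether other groups at this place, such as fluoro, methoxy or an amine, would show the same dependence on the core. They also leave open whether the gap would persist if a nitrile or a carboxylic acid took the place of the methylsulfonyl group.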